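From furan to thiophene on a shared core

The source may hold more compounds than are shown below. What is called first, only, known or untested is meant among the compounds shown, and "the series" means these compounds.

Measured in a functional assay on A549 cells (Homo sapiens), read by MTT assay, with a stated time of 72 h; a higher number here means a weaker inhibitor, a lower number a stronger inhibitor:
Compound 1 `COc1nc(N)nc2c1c(-c1ccco1)cn2[C@@H]1O[C@H](CO)[C@@H](O)[C@H]1O`: > 20000 nM
Compound 2 `COc1nc(N)nc2c1c(-c1ccoc1)cn2[C@@H]1O[C@H](CO)[C@@H](O)[C@H]1O`: > 20000 nM

Both entries are limits, not numbers. Compound 2 stands at a limit, > 20000 nM. Compound 1 gives no number either, so the whole picture so far is the limit of > 20000 nM in this assay, at which 2 of the 2 values shown sit. For the measured compounds named here, the only measured step is a step that the two limits leave unreadable from compound 1 to compound 2, and it therefore gives no size to carry forward.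

Next comes compound 3 `COc1nc(N)nc2c1c(-c1cccs1)cn2[C@@H]1O[C@H](CO)[C@@H](O)[C@H]1O`, which keeps the shared core and changes one group: thiophen-2-yl in place of furan-3-yl on an aromatic carbon. Each group is a five-membered aromatic ring with 1 hetero atom. With no measured size to build on, no clear shift in this assay is expected in either direction, and the estimated step is a step that the limit leaves unreadable from compound 2 to compound 3. Another limit is the likeliest result. For compound 3 the estimate is 25000 nM, with an expected range of 9000 nM to 60000 nM.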

Compound 3, half-maximal inhibitory concentration: > 20000 nM
Compound 3: only a limit was reported; the forecaster's own chance of this, stated with the estimate: 85%; the middle value does not contradict the limit.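

In this assay compound 3 gives > 20000 nM, again a limit and not a number. The steps linking compound 3 to compound 1 and compound 2 therefore cannot be read. The compounds shown leave open how strong each of the three actually is, and whether they differ at all.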